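The compounds below may be only part of what the source reports. "The series", "measured", "known", "first", "only" and "open" are said of these compounds alone.

Of the compounds shown here, three have so far been measured in an assay for inhibition of arginase-1 (Bos taurus), with a stated time of 30 min, tested at 1 mM; on this read-out lower numbers stand for less inhibition and higher numbers for more inhibition at the one concentration tested (going by the name of the read-out). Compound 1 `COCC(=N)NCCC[C@H](N)C(=O)O` gives 22%, compound 2 `COCCC(=N)NCCC[C@H](N)C(=O)O` gives 43%, and compound 3 `COCCC(=N)NCCCCN` gives 22%. Compound 2 therefore stands highest of the three, separated from each of the other two by a step beyond the scatter: a number 21 percentage points higher from compound 1 to compound 2 (beyond the scatter) and a number 21 percentage points lower from compound 2 to compound 3 (beyond the scatter).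

Compound 4 `COCCCC(=N)NCCC[C@H](N)C(=O)O` has not yet been measured. It differs from compound 2 by methoxymethyl in place of methoxy on a saturated chain carbon, two bonds along the chain from a carbon with a double bond to nitrogen. Among the measured compounds shown here, of the two measured steps, only the one from compound 1 to compound 2 bears on this change, as it is the same difference, cut one bond further out; there it gave a number 21 percentage points higher from compound 1 to compound 2 (beyond the scatter). The step from compound 2 to compound 3 concerns the carboxy group and says nothing about the methoxy-bearing chain. Whether a second lengthening of the same kind repeats the earlier gain cannot be settled from a single step, so the expected outcome in this assay is a small rise or no change beyond the scatter, and the estimate is a number 7 percentage points higher from compound 2 to compound 4 (within the scatter). On that basis compound 4 is expected to give about 50%, within a range from 30% to 70%.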

Compound 4, a percentage reported as inhibition, at one concentration (the size of the read-out at that concentration, not a potency): 20%
Compound 4: the middle estimate sits 30 percentage points above what was measured; the measured number lies below the stated range.
By their numbers in this assay, from the lowest: compounds 4, 1 and 3 (each within the scatter of the next); then compound 2.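

In this assay, a further lengthening at this position does not repeat the earlier gain: going from 2-methoxyethyl to 3-methoxypropyl gives a number 23 percentage points lower from compound 2 to compound 4 (beyond the scatter), so among the three chains shown, only the middle one, in compound 2, stands apart. The two outer chains, methoxymethyl and 3-methoxypropyl, cannot be told apart, with a number 2 percentage points lower from compound 1 to compound 4 (within the scatter), so the same added carbon raised the number at one chain length and lowered it at the next. No measurement in hand accounts for this turn.

The compounds shown leave open whether the result depends on the length of the chain alone or also on where its ether oxygen sits, a question that an all-carbon chain such as propyl or butyl, or a chain ending in a hydroxy group or an amine, could help to separate. Among the compounds shown here, they also leave open whether replacing the carboxy group with hydrogen would have the same effect on the methoxymethyl or 3-methoxypropyl chains, since that change is seen only with the 2-methoxyethyl chain.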